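The source may hold more compounds than are shown below. What is called first, only, known or untested is meant among the compounds shown, and "the series" means these compounds.

Notes on the series. Compound 1 `O=C(O)CNC(=O)c1c(O)c2c(n(Cc3ccc(C(F)(F)F)cc3)c1=O)COC2` and compound 2 `O=C(O)CNC(=O)c1c(O)c2c(n(Cc3ccc(Cl)cc3)c1=O)COC2` share one core and differ only in the group on the benzyl ring. In an assay on Sf9 cells for inhibition of prolyl hydroxylase EGLN2 (Homo sapiens), read by TR-FRET, with stated times of 30 min and 2 h (a lower number here means a stronger inhibitor, a higher number a weaker inhibitor), compound 1 gives 3.6 nM, and in this assay compound 2 gives 2.1 nM. Within the data shown here, the single measured step is a 1.7-fold lower number from compound 1 to compound 2 (0.23 log units; within the scatter). Compound 2 therefore stands beside compound 1 with the two numbers inside the scatter of each other, and neither compound can be called the stronger on this evidence.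

Compound 3 `O=C(O)CNC(=O)c1c(O)c2c(n(Cc3cc(F)c(F)cc3F)c1=O)COC2` is the next member and is still to be measured. Its change from compound 2 is 2,4,5-trifluorophenyl in place of 4-chlorophenyl on a saturated chain carbon bound to an aromatic nitrogen. Among the measured compounds shown here, no measured step bears directly on this change; the only step available, a 1.7-fold lower number from compound 1 to compound 2 (0.23 log units; within the scatter), exchanged one group for another on the same ring and moved the number within the scatter. On that basis no step beyond the scatter is expected in this assay, in either direction. Compound 3 is accordingly expected to give about 3 nM in this assay, with a range of 1 nM to 9 nM. The expected step of a 1.4-fold higher number from compound 2 to compound 3 (0.15 log units; within the scatter) would thus lie within the scatter.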

Compound 3, half-maximal inhibitory concentration: 3.1 nM
Compound 3: the middle estimate sits 1.0-fold (0.01 log units) below what was measured; measured number inside the range.
By their numbers in this assay, from the lowest: compounds 2, 3 and 1 (each within the scatter of the next).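

Working from compound 2 to compound 3, the change at this position is larger than the earlier one: the whole 4-chlorophenyl gives way to 2,4,5-trifluorophenyl on a saturated chain carbon bound to an aromatic nitrogen, with the chlorine gone, three fluorines present and the group growing from 7 to 9 heavy atoms. In this assay, this gives a 1.5-fold higher number from compound 2 to compound 3 (0.17 log units; within the scatter), so the earlier result, which involved one group exchanged on the ring, now extends to a change in both the halogen and the number of ring substituents, again without a step beyond the scatter. Nothing available explains why this exchange leaves the two numbers within the scatter of each other.

All three groups shown at this position are phenyl rings carrying chlorine, fluorine or trifluoromethyl, so the series does not yet show how far this insensitivity extends, and it could end with an amine or a methoxy group on the ring, or with a longer chain carrying the ring. On these data alone, the shared core and its carboxylic acid stay the same throughout, so what a change in either would do to the number also remains open.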